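The source may hold more compounds than are shown below. What is called first, only, known or untested is meant among the compounds shown, and "the series" means these compounds.

Working notes, series on the shared core of compound 1.

Three compounds have numbers in a functional assay on cells (T-cell, Homo sapiens) for inhibition; on this read-out higher numbers stand for weaker inhibition and lower numbers for stronger inhibition. Compound 1 `COc1ccc(-c2cnc3nc(N)nc(N4CCN(C(=O)COc5ccccc5)CC4)c3n2)cc1OC` gives 4 nM. Compound 2 `COc1ccc(-c2cnc3nc(N)nc(N4CCN(C(=O)CCc5ccccc5)CC4)c3n2)cc1OC` gives 100 nM. Compound 3 `COc1ccc(-c2cnc3nc(N)nc(N4CCN(C(=O)COc5ccc(Cl)cc5)CC4)c3n2)cc1OC` gives 0.5 nM, the lowest of the three, with compound 1 nearest and compound 2 furthest. The measured steps are an 8.0-fold lower number from compound 1 to compound 3 (0.90 log units; beyond the scatter), a 25-fold higher number from compound 1 to compound 2 (1.40 log units; beyond the scatter) and a 200-fold lower number from compound 2 to compound 3 (2.30 log units; beyond the scatter).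

Compound 4 `COc1ccc(-c2cnc3nc(N)nc(N4CCN(C(=O)Nc5ccccc5)CC4)c3n2)cc1OC` is not yet measured. It differs from compound 3 by anilino in place of (4-chlorophenoxy)methyl on a carbonyl carbon. Among the compounds with values here, two measured steps bear on this. First, compound 4 lacks the chloro, which reverses the step of an 8.0-fold lower number from compound 1 to compound 3 (0.90 log units; beyond the scatter), so an increase of about that size is expected from that part alone. Second, the step of a 25-fold higher number from compound 1 to compound 2 (1.40 log units; beyond the scatter) shows that what sits on this carbonyl carbon matters a great deal, although the change from (4-chlorophenoxy)methyl to anilino has no direct precedent in the series, and the gain of a hydrogen-bond donor here has not been tested. A higher number than for compound 3 is therefore expected, in the region of compound 1 or above, with wide uncertainty. The expected step is a 30-fold higher number from compound 3 to compound 4 (1.48 log units; beyond the scatter). Compound 4 is estimated at 15 nM, within the range 3 nM to 100 nM.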

Compound 4, half-maximal inhibitory concentration: 3.4 nM
The estimate for compound 4 lay 4.4-fold (0.64 log units) above the measured number; the range from low to high includes it.
By their numbers in this assay, from the lowest: compound 3; then compounds 4 and 1 (each within the scatter of the next); then compound 2.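

In this assay, anilino and phenoxymethyl on this carbonyl carbon cannot be told apart, with a 1.2-fold lower number from compound 1 to compound 4 (0.07 log units; within the scatter), so the change of the chain link from the oxygen of compound 1 to the nitrogen of compound 4 has no readable effect here. Phenethyl is the group that stands apart, with a 29-fold lower number from compound 2 to compound 4 (1.47 log units; beyond the scatter), and this shows that compound 2 and not compound 1 is the exception among the three groups without chloro, the link in compound 2 being carbon only. The remaining gap, a 6.8-fold higher number from compound 3 to compound 4 (0.83 log units; beyond the scatter), is close in size to the gain seen on adding the chloro, an 8.0-fold lower number from compound 1 to compound 3 (0.90 log units; beyond the scatter), so the step to compound 4 can be read as the absence of chloro, with anilino itself adding little in either direction.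

Nothing in hand gives a reason for the position of phenethyl relative to the other two groups. Open too, from the compounds shown here alone, is whether the gain from chloro carries over to the anilino series, as 4-chloroanilino would show, and whether the amide hydrogen matters at all, as N-methylanilino would show.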